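Hydrazone series: phenol in place of methoxy

The source may report more compounds than this note shows. Statements on the series, on what has been measured and on what is new or still open speak of the compounds shown alone.

The series shares one core, seen in compound 1 `COc1ccccc1/C=N/Nc1nc2ccccc2nc1Cc1ccccc1`, which in an assay on isolated protein for inhibition of Amine oxidase [flavin-containing] A (Homo sapiens), read by spectrophotometry (a lower number here means a stronger inhibitor, a higher number a weaker inhibitor), gives 83 nM. Compound 2 `COc1ccc(/C(C)=N/Nc2nc3ccccc3nc2Cc2ccccc2)cc1` gives 89 nM in this assay, and compound 3 `COc1ccc(/C=N/Nc2nc3ccccc3nc2Cc2ccccc2)cc1` gives 63 nM. Compound 1 stands second highest of the three numbers; its nearest neighbour is compound 2 and its furthest is compound 3, and both gaps lie within the scatter, so no order among the three is established.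

Compound 4 `Oc1ccc(/C=N/Nc2nc3ccccc3nc2Cc2ccccc2)cc1` has not been measured. Its change from compound 1 is 4-hydroxyphenyl in place of 2-methoxyphenyl on a carbon with a double bond to nitrogen. Of the measured steps, only a 1.3-fold lower number from compound 1 to compound 3 (0.12 log units; within the scatter) bears on it: it replaces 2-methoxyphenyl with 4-methoxyphenyl and stays within the scatter. For the measured compounds named here, no measured pair shows what a hydroxy group gives in place of a methoxy group, so that part of the change has no precedent. Going by the values given here, with the only relevant step flat, the expectation in this assay is a step near zero, a 1.1-fold lower number from compound 1 to compound 4 (0.04 log units; within the scatter), with no direction beyond the scatter. The estimate for compound 4 is therefore 75 nM, with a range from 35 nM to 160 nM kept wide to cover the unmeasured exchange of the substituent.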

Compound 4, half-maximal inhibitory concentration: 3.4 nM
Beside the measured number, compound 4's estimate is 22-fold (1.34 log units) above it; measured number outside the range, below it.
By their numbers in this assay, from the lowest: compound 4; then compounds 3, 1 and 2 (each within the scatter of the next).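

In this assay, for the compounds shown here, the single exchange of hydrogen for methyl on an oxygen on an aromatic ring gives a 19-fold lower number from compound 3 to compound 4 (1.27 log units; beyond the scatter), the first step beyond the scatter, and it shows that this position responds strongly to a hydroxy group where the methoxy compounds gave no separation. Moving the methoxy group alone gives a 1.3-fold lower number from compound 1 to compound 3 (0.12 log units; within the scatter), which stays within the scatter, so the large change in a 24-fold lower number from compound 1 to compound 4 (1.39 log units; beyond the scatter) goes with the hydroxy group and not with the move from 2-methoxyphenyl to a 4-substituted phenyl. No data at hand bear on why the exchange has an effect of this size.

As far as these compounds go, it remains open whether the hydroxy group must stand as in 4-hydroxyphenyl, since 2-hydroxyphenyl has no value here, and whether an amine or a carboxylic acid in its place would keep the low number. Also open, from the compounds shown here alone, is whether the hydroxy gain carries over to the methyl-bearing carbon with a double bond to nitrogen of compound 2, or to other groups in place of that methyl, such as ethyl.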